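Ethyl to propyl: a chain extension at the assay limit

The source may hold more compounds than are shown below. What is called first, only, known or untested is meant among the compounds shown, and "the series" means these compounds.

Measured compounds:
compound 1 `CCc1ccccc1OS(=O)(=O)c1cccc(NC(=O)NCCCCl)c1`: 25000 nM
compound 2 `Cc1ccccc1NS(=O)(=O)c1ccc(NC(=O)NCCCCl)cc1`: > 200000 nM
compound 3 `CCc1ccccc1NS(=O)(=O)c1ccc(NC(=O)NCCCCl)cc1`: > 200000 nM

In a functional assay on MCF7 cells (Homo sapiens) for cytotoxicity, read by sulforhodamine B assay, with a stated time of 48 h (on this read-out lower numbers stand for stronger inhibition and higher numbers for weaker inhibition), compound 1 gives 25000 nM. For compound 2 the value > 200000 nM is a limit of the assay and not a number. For compound 3 the value > 200000 nM is likewise a limit of the assay and not a number. Compound 3 therefore stands at the limit, and of the three compounds only compound 1 has a measured number. The step that the two limits leave unreadable from compound 2 to compound 3 cannot be read because both of its ends sit at the limit of > 200000 nM in this assay, at which 2 of the 3 values shown sit. Going by the values given here, compound 1 differs from compound 3 at several places, so its value shows only that a number was reached there.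

Compound 4 `CCCc1ccccc1NS(=O)(=O)c1ccc(NC(=O)NCCCCl)cc1` differs from compound 3 by methyl in place of hydrogen on a saturated chain carbon, two bonds along the chain from an aromatic carbon. Among the compounds with values here, the only measured step that bears on this change is the one from compound 2 to compound 3, and its size is not readable. No direction can be derived from what has been measured. Since compound 3 sits at the limit, compound 4 is expected to remain at or near it. The estimated step that the limit leaves unreadable from compound 3 to compound 4 is expected to be no larger than the scatter. Compound 4 is thus estimated at 250000 nM, within a range from 80000 nM to 800000 nM.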

Compound 4, half-maximal inhibitory concentration: 35000 nM
Estimate against measurement, compound 4: 7.1-fold (0.85 log units) above, outside the stated range (below it).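

In this assay, going by these compounds alone, the change from 2-ethylphenyl to 2-propylphenyl gives an at least 5.7-fold lower number from compound 3 to compound 4 (0.75 log units; beyond the scatter), the first step at this position whose size can be read at all. Ethyl in place of hydrogen on the saturated chain carbon bound to an aromatic carbon gives an at least 5.7-fold lower number from compound 2 to compound 4 (0.75 log units; beyond the scatter), so among the compounds sharing this core, the propyl group of compound 4 is the one that gives a measured number, where the methyl and ethyl groups do not. Both steps give only a minimum size and the step from compound 2 to compound 3 cannot be read, because compound 2 and compound 3 each carry a limit and not a number: the limit of > 200000 nM in this assay, at which 2 of the 4 values shown sit.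

The compounds shown leave open whether the number keeps falling with a longer chain such as butyl or pentyl, or whether it depends on a straight chain, as a branched isopropyl group at the same place could show. They also leave open whether a terminal amine or a carboxylic acid on the propyl chain would keep the number that compound 4 reaches.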